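The source may report more compounds than this note shows. Statements on the series, on what has been measured and on what is new or still open speak of the compounds shown alone.

Measured so far in a functional assay on MIA PaCa-2 cells (Homo sapiens) for inhibition, read by MTT assay, with a stated time of 24 h; a lower number here means a stronger inhibitor of growth, a higher number a weaker inhibitor of growth:
- compound 1 `N[C@@H](CCC(=O)OC[C@H]1O[C@@H](n2cc(F)c(=O)[nH]c2=O)C[C@@H]1OC(=O)CC[C@H](N)C(=O)O)C(=O)O`: 3300000 nM
- compound 2 `N[C@@H](CC(=O)OC[C@H]1O[C@@H](n2cc(F)c(=O)[nH]c2=O)C[C@@H]1O)C(=O)O`: 3600000 nM
- compound 3 `CC(C)[C@H](N)C(=O)OC[C@H]1O[C@@H](n2cc(F)c(=O)[nH]c2=O)C[C@@H]1O`: 4200000 nM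

Compound 3 stands within the scatter of both compound 1 and compound 2. The next step leads to compound 4 `N[C@@H](CCC(=O)OC[C@H]1O[C@@H](n2cc(F)c(=O)[nH]c2=O)C[C@@H]1O)C(=O)O`: 3-amino-3-carboxypropyl in place of 1-amino-2-methylpropyl on a carbonyl carbon. In words, this is 3-amino-3-carboxypropyl in place of 1-amino-2-methylpropyl on a carbonyl carbon. The closest measured step is a 1.2-fold higher number from compound 2 to compound 3 (0.07 log units; within the scatter), which also changes the group on that carbonyl carbon and stays within the scatter. Compound 1, which also carries 3-amino-3-carboxypropyl, gives 3300000 nM. No step beyond the scatter is therefore expected in this assay. The expected change is a 1.2-fold lower number from compound 3 to compound 4 (0.08 log units; within the scatter). Compound 4 is estimated at 3500000 nM, with an expected range of 1800000 nM to 6500000 nM.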

Compound 4, concentration for 50% growth inhibition: 2400000 nM
Compound 4: the middle estimate sits 1.5-fold (0.16 log units) above what was measured, within the range that was stated.
By their numbers in this assay, from the lowest: compounds 4, 1, 2 and 3 (each within the scatter of the next).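

In this assay the change on the carbonyl carbon to 3-amino-3-carboxypropyl gives a 1.8-fold lower number from compound 3 to compound 4 (0.24 log units; within the scatter) and the comparison with the shorter amino acid chain gives a 1.5-fold lower number from compound 2 to compound 4 (0.18 log units; within the scatter) as well, so neither the group nor its chain length moves the number beyond the scatter here. Replacing (3-amino-3-carboxypropyl)carbonyl with hydrogen on the oxygen on a saturated carbon likewise gives only a 1.4-fold lower number from compound 1 to compound 4 (0.14 log units; within the scatter) and leaves the series flat across both sites. Still open, as far as these compounds go, is whether a plain butyl chain with neither amine nor carboxylic acid on this carbonyl carbon would leave that flat picture intact. No independent measurement bears on why these steps stay so small.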